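Terminal hydroxy removal on the chain of compound 2

The source may hold more compounds than are shown below. What is called first, only, known or untested is meant among the compounds shown, and "the series" means these compounds.

In a functional assay, read by fluorescence and spectrophotometry, with a stated time of 1 h (on this read-out higher numbers stand for an effect only at larger amounts of compound and lower numbers for an effect already at smaller amounts), compound 2 `O=S(=O)(/C=C/c1ccc(O)c(O)c1)CCCCCCCCO` gives 6700 nM. Compound 1 `CCCCCCS(=O)(=O)/C=C/c1ccc(O)c(O)c1` gives 7300 nM and compound 3 `CC(C)(C)OC(=O)N1CCCC1CS(=O)(=O)/C=C/c1ccc(O)c(O)c1` gives 7100 nM in this assay, so the three numbers lie within the scatter of one another and no order among them can be read. Compound 4 `CCCCCCCCS(=O)(=O)/C=C/c1ccc(O)c(O)c1` has not been measured. Its difference from compound 2 is hydrogen in place of hydroxy on a saturated chain carbon, eight bonds along the chain from a sulfonyl sulfur. Among the compounds with values here, the one measured step that bears on this is a 1.1-fold lower number from compound 1 to compound 2 (0.04 log units; within the scatter), where the 2-hydroxyethyl added onto the chain left this assay unchanged. No shift beyond the scatter is therefore expected, and compound 4 is estimated at 7000 nM, with a range from 3500 nM to 14000 nM. The step of a 1.0-fold higher number from compound 2 to compound 4 (0.02 log units; within the scatter) is thus expected to stay within the scatter.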

Compound 4, half-maximal effective concentration: 6400 nM
Beside the measured number, compound 4's estimate is 1.1-fold (0.04 log units) above it, within the range that was stated.
By their numbers in this assay, from the lowest: compounds 4, 2, 3 and 1 (each within the scatter of the next).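

Hydrogen in place of hydroxy on this carbon gives a 1.0-fold lower number from compound 2 to compound 4 (0.02 log units; within the scatter) in this assay and shows that the hydroxy is not needed to hold the number on this read-out. Ethyl in place of hydrogen on the chain gives a 1.1-fold lower number from compound 1 to compound 4 (0.06 log units; within the scatter) and so also stays within the scatter, which means the two changes at this end of the chain leave the number in the same place. No measurement at hand offers an explanation for this flat result.

As far as these compounds go, whether an amine, a carboxylic acid or a longer chain at this position would move the number beyond the scatter stays open.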